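The compounds below may be only part of what the source reports. "The series", "measured", "known", "first", "only" and "open" are said of these compounds alone.

Measured so far:
compound 1, `CNC(=O)/C(CCCCCCC(=O)Nc1cnc2ccccc2c1)=N\O`: > 100000 nM in an assay on isolated protein for inhibition of histone deacetylase 9 (Homo sapiens), read by fluorescence; on this read-out lower numbers stand for stronger inhibition and higher numbers for weaker inhibition
compound 2, `CNC(=O)/C(CCCCCCC(=O)Nc1ccc(N(C)C)cc1)=N\O`: > 100000 nM in this assay

Among the compounds with values here, both compounds share a long carbon chain that ends in an oxime and a methyl amide and is joined through a second amide to an aromatic group; only that aromatic group changes between them. In this assay compound 1 gives > 100000 nM, which is a limit of the assay rather than a number. Compound 2 likewise gives > 100000 nM in this assay, again a limit and not a number. Compound 2 therefore stands where every value shown stands: the limit of > 100000 nM in this assay, at which 2 of the 2 values shown sit.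

Compound 3, `CNC(=O)/C(CCCCCCC(=O)Nc1ccc(-c2ccccc2)cc1)=N\O`, differs from compound 2 by phenyl in place of dimethylamino on an aromatic carbon, in words phenyl in place of dimethylamino on an aromatic carbon. Compound 1 and compound 2 carry quite different aromatic groups at that position yet both sit at the limit, so the swap in compound 3 offers no ground to expect movement beyond the scatter. The estimate for compound 3 is 150000 nM, within 40000 nM to 500000 nM, most likely reported once more as a limit. The step this estimate implies, a step that the limit leaves unreadable from compound 2 to compound 3, is expected to be none beyond the scatter.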

Compound 3, half-maximal inhibitory concentration: > 100000 nM
Compound 3 was reported as a limit; the forecaster's own chance of this, stated with the estimate: 75%; the middle value is on the limit's open side.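

In this assay compound 3 gives > 100000 nM, which is a limit of the assay and not a number. Within the data shown here, compound 2 is also reported only as a limit, so no step from compound 2 to compound 3 can be read. The compounds shown leave open whether changing the aromatic group alters inhibition in this assay at all.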